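This account rests on a few compounds, and the source may have more. Where it says the series, first, only, none or still open, it means among the compounds named here.

Among the compounds with values here, compound 1 `CCN(CC)c1ccc2cc(C(=O)NC(C)C)c(=O)oc2c1` is the only compound here with an actual number: in a functional assay on HeLa cells (Homo sapiens) for cytotoxicity, read by MTT assay, with a stated time of 72 h (on this read-out lower numbers stand for stronger inhibition and higher numbers for weaker inhibition), compound 1 gives 73000 nM. Compound 2 `NNC(=O)c1cc2ccc(OCc3ccc([N+](=O)[O-])cc3)cc2oc1=O` reaches only a limit of this assay, > 100000 nM, which is the limit of > 100000 nM in this assay, at which 1 of the 2 values shown sits. Compound 3 `CCN(CC)c1ccc2cc(C(=O)N/N=C(/C)c3cccs3)c(=O)oc2c1` differs from compound 1 by a group of 8 heavy atoms (6 carbon, 1 nitrogen, 1 sulfur; one five-membered aromatic ring with 1 hetero atom) in place of a group of 3 heavy atoms (3 carbon; no ring), on an amide-type nitrogen. Within the data shown here, no measured pair of compounds shows the effect of such a change, so the expectation rests on compound 1 alone. A modest gain in potency, somewhat beyond the usual scatter, is expected, a 2.4-fold lower number from compound 1 to compound 3 (0.39 log units; beyond the scatter). Compound 3 is therefore estimated to give about 30000 nM in this assay, with a range from 5000 nM to 150000 nM.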

Compound 3, half-maximal inhibitory concentration: > 100000 nM
Compound 3: only a limit was reported; the forecaster's own chance of this, stated with the estimate: 25%; at least 3.3-fold (0.52 log units) between middle value and limit.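

Putting the group with the five-membered aromatic ring in place of the isopropyl on the amide-type nitrogen brings no gain in this assay, where compound 3 reaches only a limit. The step reads an at least 1.3-fold higher number from compound 1 to compound 3 (0.13 log units; that floor lies within the scatter), so compound 3 cannot be called clearly weaker. The true size of the change stays unknown because the reading stops at the top of the range: the limit of > 100000 nM in this assay, at which 2 of the 3 values shown sit.

On these data alone, whether this large group costs activity at all remains open. So does whether a smaller group on this nitrogen, such as a methyl or a cyclopropyl, or a longer chain ending in an amine would lower the number.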